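Swapping a Fluorine for a Nitrile on a Weak Binder

The source may report more compounds than this note shows. Statements on the series, on what has been measured and on what is new or still open speak of the compounds shown alone.

Of the compounds shown here, two have been measured in an assay on HEK293 cells for inhibition of sodium channel protein type 3 subunit alpha (Homo sapiens), read by electrophysiology, with a stated time of 3.5 min; a lower number here means a stronger inhibitor, a higher number a weaker inhibitor. Compound 1 `C[C@H](NC1CCCc2cc(OCc3ccccc3F)ccc21)C(N)=O` gives 63100 nM in this assay. Compound 2 `NC(=O)[C@@H]1CC[C@H](c2ccc(OCc3ccc(F)cc3)cc2)N1` carries a different core, and in this assay compound 2 is reported only as a limit, > 63000 nM, which marks the edge of what the assay can read rather than a number. This places compound 2 at the limit of > 63000 nM in this assay, at which 1 of the 2 values shown sits, so where compound 2 truly stands within the weak range cannot be told from the data.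

Compound 3 `N#Cc1ccccc1COc1ccc([C@H]2CC[C@@H](C(N)=O)N2)cc1` keeps the core of compound 2 and differs in one place: 2-cyanophenyl in place of 4-fluorophenyl on a saturated chain carbon bound to an oxygen on an aromatic ring. Nothing measured here speaks to what a 2-cyanophenyl does in place of a 4-fluorophenyl on this core, so no cause can be given for any shift. Because compound 2 sits at the limit, the step is expected to be small, a number no higher from compound 2 to compound 3 (the limit leaves the size open), or none beyond the scatter, with a fair chance that compound 3 is again reported only as a limit. Compound 3 is therefore estimated to give 63000 nM in this assay, in a range from 20000 nM to 200000 nM.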

Compound 3, half-maximal inhibitory concentration: > 63000 nM
Compound 3: no number, only a limit (the forecaster's own chance of this, stated with the estimate: 60%); the middle value sits exactly at the limit.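

Going by these compounds alone, compound 2 and compound 3 are both reported in this assay only as limits, so no step between them can be read, and the count now stands as follows: the limit of > 63000 nM in this assay, at which 2 of the 3 values shown sit. Still open, on these data alone, is whether 2-cyanophenyl in place of 4-fluorophenyl changes inhibition on this core at all, and where either compound truly stands beyond its limit.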